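A few compounds are considered here, and "the series" means these few. Any claim that something is new, unique, unknown or untested is made for them only; others in the source may bear on it.

Of the compounds shown here, three have been measured in an ADME assay on RAW264.7 cells (Mus musculus) for cytotoxicity, read by MTT assay, with a stated time of 24 h; on this read-out higher numbers stand for lower toxicity in this test and lower numbers for higher toxicity in this test. Compound 3, `O=C(Nc1ccc(Br)cc1F)c1cc(F)ccc1O`, gives 7900 nM. Compound 1, `O=C(Nc1ccc(Br)cc1F)c1cc(I)ccc1O`, differs from it in one place, (iodo in place of fluoro on an aromatic carbon), and in this assay compound 1 gives 8400 nM; the step of a 1.1-fold higher number from compound 3 to compound 1 (0.03 log units; within the scatter). Compound 2, `O=c1oc2ccc(F)cc2c(=O)n1-c1ccc(F)cc1F`, is built on another core, and the difference between the two cores is not broken down here. In this assay compound 2 gives 19900 nM, the highest of the three numbers, and its gaps to compound 1 and to compound 3 are both beyond the scatter.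

Compound 4, `O=c1oc2ccc(F)cc2c(=O)n1-c1ccc(I)cc1F`, has not yet been measured. It stands to compound 2 as compound 1 stands to compound 3: iodo in place of fluoro on an aromatic carbon. The surroundings of the place are not the same word for word: in compound 3 the changed carbon is meta to a large group and para to a hydroxy group, whereas in compound 2 it is meta to a fluoro group and para to a large group, so this is the same kind of change rather than the same change. For the measured compounds named here, the one measured instance of it, the step from compound 3 to compound 1, stayed within the scatter. In this assay the expected outcome is a 1.1-fold higher number from compound 2 to compound 4 (0.02 log units; within the scatter), estimated because a 1.1-fold higher number from compound 3 to compound 1 (0.03 log units; within the scatter) was a small step. Compound 4 is therefore estimated to give 21000 nM, with a range from 10000 nM to 42000 nM.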

Compound 4, half-maximal cytotoxic concentration: 6000 nM
Estimate against measurement, compound 4: 3.5-fold (0.54 log units) above; measured number outside the range, below it.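

In this assay, iodo in place of fluoro on an aromatic carbon gave a 3.3-fold lower number from compound 2 to compound 4 (0.52 log units; beyond the scatter), a step towards higher toxicity in this test. The same change therefore did not carry over unaltered from one core to the other, and the two steps differ: the same change on two cores in this assay, a 1.1-fold higher number (0.03 log units; within the scatter) from compound 3 to compound 1 and a 3.3-fold lower number (0.52 log units; beyond the scatter) from compound 2 to compound 4, 3.5-fold (0.55 log units) apart, beyond the scatter of two such steps

What this does not show is why they differ: the cores are not the same and neither are the surroundings of the changed carbon, and with a single pair on each core these two differences cannot be told apart, nor can it be said whether either step would hold for other pairs on the same core.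

The compounds shown leave open whether the lower number belongs to iodo alone or would also appear with a chloro or a methoxy group at the same place on the core of compound 2. They also leave open how an amine at that place would read in this assay, and whether a third core would follow either of the two steps or neither of them.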